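Shifting a bromine substituent: expected cytotoxicity of compound 4

A few compounds are considered here, and "the series" means these few. Any claim that something is new, unique, unknown or untested is made for them only; others in the source may bear on it.

Compound 1 `COC(=O)c1ccc(NCc2cncn2Cc2cccc(Br)c2)cc1-c1ccccc1`: in a toxicity assay on NIH3T3 cells (Mus musculus) for cytotoxicity, read by resazurin assay (on this read-out lower numbers stand for an effect already at smaller amounts and higher numbers for an effect only at larger amounts of compound), compound 1 gives > 10000 nM, a limit of the assay rather than a number.
Compound 2 `Cc1cccc(-c2cccc(NCc3cncn3Cc3ccccc3)c2)c1`: compound 2 gives > 1000 nM, also a limit.
Compound 3 `c1ccc(-c2ccc(Cn3cncc3CNc3ccc(-c4ccccc4)cc3)cc2)cc1`: compound 3 gives > 10000 nM, again a limit.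

All three values are limits, so compound 1 stands among them without a measured number. It sits at the limit of > 10000 nM in this assay, at which 2 of the 3 values shown sit, and compound 2 sits at the limit of > 1000 nM in this assay, at which 1 of the 3 values shown sits. Compound 4 `COC(=O)c1ccc(NCc2cncn2Cc2ccc(Br)cc2)cc1-c1ccccc1` differs from compound 1 by 4-bromophenyl in place of 3-bromophenyl on a saturated chain carbon bound to an aromatic nitrogen. Among the measured compounds shown here, no step between measured compounds is available, so the size of this change can only be expected: a step within the scatter in this assay, in no clear direction. Compound 4 is therefore expected to give 20000 nM, between 8000 nM and 60000 nM, most likely again a limit. The step that the limit leaves unreadable from compound 1 to compound 4 is expected to be essentially none.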

Compound 4, half-maximal effective concentration: > 10000 nM
Compound 4 gave a limit, no number; the forecaster's own chance of this, stated with the estimate: 80%; the middle value lies beyond the limit too.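

Compound 1 and compound 4 each give only a limit in this assay, not a number, and the step between them cannot be read. The compounds shown leave open whether 4-bromophenyl and 3-bromophenyl differ in cytotoxicity at all.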